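The compounds below may be only part of what the source reports. "The series", "measured", "known", "first", "only" and "open" are said of these compounds alone.

Compounds measured so far:

Compound 1, `CNC1=CC(=O)c2c(cnc(C)c2C)C1=O`, gives 12400 nM in a functional assay on LXFL 529L cells (Homo sapiens) for cytotoxicity, read by propidium iodide staining, with a stated time of 4 days; a lower number here means a stronger inhibitor, a higher number a weaker inhibitor.
Compound 2, `CNC1=CC(=O)c2cc(C)ncc2C1=O`, gives 4880 nM in this assay.

Among the two numbers known, compound 2 stands lowest: the only other compound, compound 1, sits higher by a 2.5-fold lower number from compound 1 to compound 2 (0.41 log units; beyond the scatter), a step brought about by hydrogen in place of methyl on an aromatic carbon. The next compound, compound 3, `Cc1cc2c(cn1)C(=O)C(NCl)=CC2=O`, has not yet been measured in this assay. It differs from compound 2 by chloro in place of methyl on an amine nitrogen.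

Within the data shown here, none of the measured steps bears directly on this change. Among the measured compounds shown here, the single step known, a 2.5-fold lower number from compound 1 to compound 2 (0.41 log units; beyond the scatter), concerns an aromatic carbon, whereas the change to compound 3 sits on an amine nitrogen; it shows only that a one-atom exchange on this core can move the number by a modest, beyond-scatter amount. With no closer guide, a step in either direction is possible, and no direction is favoured. Compound 3 is therefore expected to give about 5000 nM, within 1500 nM to 16000 nM, which means an expected step of a 1.0-fold higher number from compound 2 to compound 3 (0.01 log units; within the scatter).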

Compound 3, half-maximal inhibitory concentration: 1540 nM
Compound 3: middle estimate off by 3.2-fold (0.51 log units), on the high side; the measured number falls inside the stated range.
By their numbers in this assay, from the lowest: compound 3; then compound 2; then compound 1.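

Among these compounds, the change on the amine nitrogen moves the number in this assay: the step of a 3.2-fold lower number from compound 2 to compound 3 (0.50 log units; beyond the scatter) shows that this position is not silent, which the earlier compounds could not show, since their only step lay on an aromatic carbon. The exchange of methyl for chloro leaves the ring count, the heavy-atom count and the counts of hydrogen-bond donors and acceptors unchanged, so the step appears without any difference in these computed counts. No measurement among those available explains why the number falls with this exchange.

As far as these compounds go, a single exchange on the amine nitrogen cannot show a trend, so it remains open whether a bromo, a fluoro, or a longer chain such as ethyl or propyl at that place would lower the number further, leave it unchanged or raise it. From the compounds shown here alone, it also remains open whether the chloro on the amine nitrogen would give a similar step on the core of compound 1, or with a methoxy or an amine on the aromatic carbon where that core carries its extra methyl.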